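This account rests on a few compounds, and the source may have more. Where it says the series, first, only, none or still open, it means among the compounds named here.

Compound 2 `COc1cc[nH]c1/C=C1\C(=O)Nc2ccc(F)c(C#C[C@@H](N)CO)c21` gives 300 nM in a functional assay on MDA-MB-435 cells (Homo sapiens) for inhibition (on this read-out higher numbers stand for weaker inhibition and lower numbers for stronger inhibition), the lowest of the three numbers in hand, although compound 1 sits within the scatter of it. Compound 1 `COc1cc[nH]c1/C=C1\C(=O)Nc2ccc(F)c(C#C[C@H](N)CO)c21` gives 320 nM; the step of a 1.1-fold lower number from compound 1 to compound 2 (0.03 log units; within the scatter) is within the scatter, which follows from the fact that compounds 1 and 2 differ only in the configuration as drawn. Compound 3 `CCN[C@H](C#Cc1c(F)ccc2c1/C(=C/c1[nH]ccc1OC)C(=O)N2)CO` gives 1160 nM, so that a 3.9-fold higher number from compound 2 to compound 3 (0.59 log units; beyond the scatter) and a 3.6-fold higher number from compound 1 to compound 3 (0.56 log units; beyond the scatter) are modest and beyond the scatter. Compound 4 `COc1cc[nH]c1/C=C1\C(=O)Nc2ccc(F)c(C#C[C@@H]3C[C@H](O)CN3)c21` has not yet been measured; it differs from compound 2 in that (4-hydroxypyrrolidin-2-yl in place of 1-amino-2-hydroxyethyl on a triple-bonded carbon). Within the data shown here, the amine nitrogen is thereby tied into a ring, and the one measured step touching that nitrogen, a 3.9-fold higher number from compound 2 to compound 3 (0.59 log units; beyond the scatter), weakened inhibition. The expected step is a 2.3-fold higher number from compound 2 to compound 4 (0.37 log units; beyond the scatter), modest and in the same direction. Compound 4 is estimated at 700 nM, in the range 250 nM to 2000 nM.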

Compound 4, half-maximal inhibitory concentration: 110 nM
Compound 4: middle estimate off by 6.4-fold (0.80 log units), on the high side; measured number below the stated range.
By their numbers in this assay, from the lowest: compound 4; then compounds 2 and 1 (each within the scatter of the next); then compound 3.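

Closing the amine nitrogen into the 4-hydroxypyrrolidin-2-yl ring on the triple-bonded carbon strengthened inhibition, with a 2.7-fold lower number from compound 2 to compound 4 (0.44 log units; beyond the scatter) and a 2.9-fold lower number from compound 1 to compound 4 (0.46 log units; beyond the scatter) against the weakening seen with the ethyl on that nitrogen in compound 3. A carbon substituent on this nitrogen therefore need not cost inhibition, and the ring form stands well apart from the open ethylamino chain, with an 11-fold lower number from compound 3 to compound 4 (1.02 log units; beyond the scatter) as the largest step in the set. Nothing in hand explains this gain. Open, on these data alone, is whether the ring or its hydroxyl carries the gain, as a plain pyrrolidin-2-yl would test. Also open, as far as these compounds go, are how an azetidine or piperidine ring would read and how the other stereoisomers of compound 4 would compare.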